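This account rests on a few compounds, and the source may have more. Where it says the series, first, only, none or still open, it means among the compounds named here.

Compound 1 `Oc1cccc(-c2cc(-c3ccccc3C(F)(F)F)cc(-c3ccccc3O)n2)c1` gives 16800 nM in a functional assay on HeLa cells (Homo sapiens) for inhibition; on this read-out lower numbers stand for stronger inhibition and higher numbers for weaker inhibition. Compound 2 `Oc1ccc(-c2cc(-c3ccccc3C(F)(F)F)cc(-c3ccccc3O)n2)cc1` gives 16500 nM in this assay, and compound 3 `Oc1ccc(-c2cc(-c3ccccc3C(F)(F)F)cc(-c3cccc(O)c3)n2)cc1` gives 17400 nM in this assay. The steps of a 1.0-fold lower number from compound 1 to compound 2 (0.01 log units; within the scatter), a 1.0-fold higher number from compound 1 to compound 3 (0.02 log units; within the scatter) and a 1.1-fold higher number from compound 2 to compound 3 (0.02 log units; within the scatter) all stay within the scatter, so the three hydroxyphenyl placements are not separated here. Compound 4 `Oc1ccc(-c2cc(-c3ccccc3C(F)(F)F)cc(-c3ccc(O)cc3)n2)cc1` is not yet measured; it differs from compound 3 by 4-hydroxyphenyl in place of 3-hydroxyphenyl on an aromatic carbon. The same kind of change occurs from compound 1 to compound 2, (4-hydroxyphenyl in place of 3-hydroxyphenyl on an aromatic carbon). The two cores differ by 4-hydroxyphenyl in place of 2-hydroxyphenyl on an aromatic carbon, so around the place the change in compound 1 stands meta to a 2-hydroxyphenyl group, whereas in compound 3 it stands meta to a 4-hydroxyphenyl group. For compound 4 a step of a 1.0-fold lower number from compound 3 to compound 4 (0.01 log units; within the scatter) is expected, because the earlier change gave a 1.0-fold lower number from compound 1 to compound 2 (0.01 log units; within the scatter). Compound 4 is therefore estimated at 17000 nM, with an expected range from 8500 nM to 34000 nM.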

Compound 4, half-maximal inhibitory concentration: > 50000 nM
Compound 4: a limit, no number; the forecaster's own chance of this, stated with the estimate: 5%; at least 2.9-fold (0.46 log units) between middle value and limit.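

In this assay compound 4 gives > 50000 nM, which is a limit of the assay and not a number. Placing 4-hydroxyphenyl in place of 3-hydroxyphenyl does not carry over from one core to the other, the new step being an at least 2.8-fold higher number from compound 3 to compound 4 (0.45 log units; beyond the scatter): the same change on two cores in this assay, a 1.0-fold lower number (0.01 log units; within the scatter) from compound 1 to compound 2 and an at least 2.8-fold higher number (0.45 log units; beyond the scatter) from compound 3 to compound 4, at least 2.9-fold (0.46 log units) apart, beyond the scatter of two such steps The change from 2-hydroxyphenyl to 4-hydroxyphenyl gives an at least 3.0-fold higher number from compound 2 to compound 4 (0.48 log units; beyond the scatter) and does not carry over either, though only a minimum is known for each gap, not its full size: the same change on two cores in this assay, a 1.0-fold higher number (0.02 log units; within the scatter) from compound 1 to compound 3 and an at least 3.0-fold higher number (0.48 log units; beyond the scatter) from compound 2 to compound 4, at least 2.9-fold (0.46 log units) apart, beyond the scatter of two such steps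

Open, on these data alone, is whether the same dependence on the core appears when an amine or a methoxy group stands in place of the hydroxyl on these rings. Also open, as far as these compounds go, is what happens when another group replaces the 2-(trifluoromethyl)phenyl group.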